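A few compounds are considered here, and "the series" means these few. Any claim that something is new, unique, unknown or untested is made for them only; others in the source may bear on it.

Compound 1 `COc1ccc2nc(C)cc(OC(C)C(=O)Nc3cc(C)cc(C)c3)c2c1` gives in a physicochemical assay for lipophilicity, read by HPLC, in phosphate buffer, measured as chromatographic lipophilicity, at pH 7.4 (on this read-out higher numbers stand for higher lipophilicity and lower numbers for lower lipophilicity), a value of 5.76.
Compound 2 `COc1ccc2nc(C)cc(OC3CCN(c4ccccc4)C3=O)c2c1` gives in this assay a value of 4.99.
Compound 3 `COc1ccc2nc(C)cc(OCC(=O)Nc3ccccc3)c2c1` gives in this assay a value of 4.28.

Among these three numbers compound 3 stands lowest. Its nearest neighbour is compound 2, whose number lies higher by a gap that is beyond the usual scatter of this measurement; the furthest is compound 1, whose number lies higher still, again beyond the scatter. Compound 4 `COc1ccc2nc(C)cc(OCC(=O)Nc3nc(C)c(C)s3)c2c1` has not yet been measured in this assay. It is derived from compound 3 by a single change: 4,5-dimethyl-1,3-thiazol-2-yl in place of phenyl on an amide-type nitrogen. Within the data shown here, no pair of measured compounds shows this particular exchange on its own, so the expected step rests on the nature of the groups that leave and enter rather than on a measured precedent. A small step is expected, if anything slightly downward, and most likely none beyond the scatter. The estimate for compound 4 in this assay is 4.15, within a range from 3.55 to 4.75, which is expected to mean a step of a number 0.13 log units lower from compound 3 to compound 4 (within the scatter).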

Compound 4, distribution coefficient: 4.24
Estimate against measurement, compound 4: 0.09 log units below; the measured number falls inside the stated range.
By their numbers in this assay, from the lowest: compounds 4 and 3 (each within the scatter of the next); then compound 2; then compound 1.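

In this assay, placing 4,5-dimethyl-1,3-thiazol-2-yl in place of phenyl on the amide-type nitrogen gives a number 0.04 log units lower from compound 3 to compound 4 (within the scatter), so this one exchange leaves the read-out indistinguishable from that of the parent compound. The exchange is not a trivial one on paper: a six-membered aromatic ring of carbon only, with no hydrogen-bond acceptors, gives way to a five-membered aromatic ring with nitrogen, sulfur and two hydrogen-bond acceptors. No measurement offered here explains why the number holds.

From the compounds shown here alone, this single pair cannot separate the ring from its two methyl groups, so the reading of a plain 1,3-thiazol-2-yl remains open. Also open, going by these compounds, is whether the number would hold with a pyridyl ring, or with a carboxylic acid or an amine on the ring at this place.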